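The compounds below may be only part of what the source reports. "The series", "measured", "known", "first", "only" and "open" are said of these compounds alone.

Going by the values given here, in an assay on blood for inhibition of C-X-C chemokine receptor type 3 (Homo sapiens), with a stated time of 30 min (on this read-out lower numbers stand for stronger inhibition and higher numbers for weaker inhibition), compound 3 `CCOc1ncc(-c2nc(C(F)(F)F)sc2N2CCN(C(=O)Cn3ccc(C(F)(F)F)n3)[C@H](C)C2)cn1` gives 90 nM, the second highest of the three numbers measured so far. Compound 2 `CCOc1ncc(-c2nc(C(F)(F)F)sc2N2CCN(C(=O)Cn3nc(C)cc3C)[C@H](C)C2)cn1` gives 60 nM in this assay, and compound 1 `CCOc1ncc(-c2nc(C(F)(F)F)sc2N2CCN(C(=O)Cn3cnc4ccccc43)[C@H](C)C2)cn1` gives 192 nM. All differences among these three sit on the group carried on the saturated chain carbon bound to the carbonyl carbon: a 3.2-fold lower number from compound 1 to compound 2 (0.51 log units; beyond the scatter) and a 2.1-fold lower number from compound 1 to compound 3 (0.33 log units; beyond the scatter), while a 1.5-fold higher number from compound 2 to compound 3 (0.18 log units; within the scatter). Compound 4 `CCOc1ncc(-c2nc(C(F)(F)F)sc2N2CCN(C(=O)Cn3cnc(C(F)(F)F)n3)[C@H](C)C2)cn1` alters that same group once more: 3-(trifluoromethyl)-1H-1,2,4-triazol-1-yl in place of 3-(trifluoromethyl)-1H-pyrazol-1-yl on a saturated chain carbon bound to a carbonyl carbon. Among the compounds with values here, no measured step covers this particular exchange. The two steps that went beyond the scatter both replaced the benzimidazolyl group by a pyrazolyl group, whereas the step between the two pyrazolyl compounds stayed within the scatter. The move from a trifluoromethyl-pyrazolyl ring to a trifluoromethyl-triazolyl ring is expected to resemble that last case rather than the first two, so the expected step is a 1.2-fold higher number from compound 3 to compound 4 (0.09 log units; within the scatter), nothing beyond the scatter. Compound 4 is therefore estimated at 110 nM in this assay, within a range of 45 nM to 270 nM.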

Compound 4, half-maximal inhibitory concentration: 524 nM
Beside the measured number, compound 4's estimate is 4.8-fold (0.68 log units) below it; measured number above the stated range.
By their numbers in this assay, from the lowest: compounds 2 and 3 (each within the scatter of the next); then compound 1; then compound 4.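

In this assay, going by these compounds alone, the one exchange of a ring carbon for a ring nitrogen at the saturated chain carbon bound to a carbonyl carbon, with the trifluoromethyl group kept, gives a 5.8-fold higher number from compound 3 to compound 4 (0.77 log units; beyond the scatter) and so goes beyond the scatter, unlike the step between the two pyrazolyl compounds. With an 8.7-fold higher number from compound 2 to compound 4 (0.94 log units; beyond the scatter) as the largest step and a 2.7-fold higher number from compound 1 to compound 4 (0.44 log units; beyond the scatter) also beyond the scatter, the triazolyl group, rather than the benzimidazolyl group, now gives the highest number of the four. Nothing at hand accounts for this step.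

The compounds shown leave open whether a second ring nitrogen raises the number with other substituents on the ring, such as the 3,5-dimethyl pair. Also open, as far as these compounds go, is how a pyrazolyl ring carrying an amine or a carboxylic acid would read out at this position.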